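Ketoamide series: terminal amide substituent and calpain-2 inhibition

The source may hold more compounds than are shown below. What is called first, only, known or untested is meant among the compounds shown, and "the series" means these compounds.

Compounds measured so far in an assay on isolated protein (Oryctolagus cuniculus) for inhibition of Calpain-2 catalytic subunit (Homo sapiens), at pH 8.0; a lower number here means a stronger inhibitor, a higher number a weaker inhibitor:
compound 1 `CCOC(=O)C(=O)C(CC)NC(=O)C(CC(C)C)NC(=O)C(CC)Oc1ccccc1`: 1400 nM
compound 2 `CCCCNC(=O)C(=O)C(CC)NC(=O)C(CC(C)C)NC(=O)OCc1ccccc1`: 50 nM
compound 3 `CCC(NC(=O)C(CC(C)C)NC(=O)OCc1ccccc1)C(=O)C(=O)NCC(C)C`: 140 nM

Compound 3 holds the second highest of the three numbers in this assay. Its nearest neighbour is compound 2, which differs from it only at the terminal amide substituent; the step of a 2.8-fold higher number from compound 2 to compound 3 (0.45 log units; beyond the scatter) is modest but beyond the scatter. Compound 1, which differs from compound 3 in several places at once, gives the highest number of the set, and no single step can be read from it.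

Compound 4 `CCC(NC(=O)C(CC(C)C)NC(=O)OCc1ccccc1)C(=O)C(=O)NCc1ccccc1` is the next member. Relative to compound 3 the change is phenyl in place of isopropyl on a saturated chain carbon bound to an amide-type nitrogen. Among the compounds with values here, the only measured step at this position is the propyl-to-isopropyl change from compound 2 to compound 3, which moved the number modestly upward. Within the data shown here, no measured pair shows a phenyl or benzyl at this position, so the direction for compound 4 cannot be read from a directly matching step. Given that the one recorded change at this position stayed within a modest range, a step no larger than that, in either direction, is the working expectation. The estimated step is a 1.8-fold lower number from compound 3 to compound 4 (0.24 log units; within the scatter). Compound 4 is therefore expected to give about 80 nM in this assay, within a range of 25 nM to 250 nM.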

Compound 4, inhibition constant: 22 nM
Beside the measured number, compound 4's estimate is 3.6-fold (0.56 log units) above it; measured number below the stated range.
By their numbers in this assay, from the lowest: compound 4; then compound 2; then compound 3; then compound 1.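

Working notes on the terminal amide substituent. Within the data shown here, this position in this assay can move the number down as well as up: the isobutyl-to-benzyl change gives a 6.4-fold lower number from compound 3 to compound 4 (0.80 log units; beyond the scatter), whereas the only earlier step at this position, a 2.8-fold higher number from compound 2 to compound 3 (0.45 log units; beyond the scatter), went upward. The benzyl group also improves on the straight chain of compound 2, with phenyl in place of propyl giving a 2.3-fold lower number from compound 2 to compound 4 (0.36 log units; beyond the scatter), so among the three compounds that differ only here, compound 4 has the lowest number and the order is benzyl, then the straight chain, then the branched chain. Nothing available explains this order or gives a reason for the drop with the benzyl group.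

Among these compounds, the single ring-bearing member leaves open whether the step follows the aromatic ring itself or simply the larger carbon count, a question that a cyclohexylmethyl group at the same position would address. Also open, going by these compounds, are the effect of a longer chain between the amide nitrogen and the ring, as in phenethyl, and of a carboxylic acid or an amine on the ring.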